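A few compounds are considered here, and "the series" means these few. Any claim that something is new, unique, unknown or untested is made for them only; others in the source may bear on it.

Compound 1 `COc1cc(/C=C2\Cc3ccccc3/C(=C\c3ccc([N+](=O)[O-])cc3)C2=O)ccc1O`: 83000 nM.
Compound 2 `COc1cc(/C=C2\Cc3ccccc3/C(=C\c3ccc([N+](=O)[O-])cc3)C2=O)cc(OC)c1OC`: > 400000 nM.
Compound 3 `COc1ccc(/C=C2\Cc3ccccc3/C(=C\c3ccc([N+](=O)[O-])cc3)C2=O)cc1`: > 400000 nM.

In a functional assay on HPC cells (Homo sapiens) for cytotoxicity (on this read-out higher numbers stand for lower toxicity in this test and lower numbers for higher toxicity in this test), compound 1 gives 83000 nM. Compound 2 gives only a limit of the assay, > 400000 nM. Compound 3 likewise gives only a limit, > 400000 nM, so no exact number is known for it. Compound 3 thus stands at the limit of > 400000 nM in this assay, at which 2 of the 3 values shown sit.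

Compound 4 `COc1ccc(/C=C2\Cc3ccccc3/C(=C\c3ccc([N+](=O)[O-])cc3)C2=O)cc1OC` differs from compound 3 in one place: methoxy in place of hydrogen on an aromatic carbon. Going by the values given here, the only measured step touching this ring is an at least 4.8-fold higher number from compound 1 to compound 3 (0.68 log units; beyond the scatter), which moved from a measured number to the limit. Compound 2, which carries three methoxy groups on the same ring, also sits only at the limit, so every compound shown with methoxy groups alone on this ring reaches the limit. Adding a second methoxy to compound 3 is therefore expected to leave the number at or near the limit, with no step beyond the scatter, a number no higher from compound 3 to compound 4 (the limit leaves the size open). Compound 4 is accordingly estimated at 400000 nM, between 150000 nM and 1000000 nM, most likely reported again only as a limit.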

Compound 4, half-maximal cytotoxic concentration: > 400000 nM
Compound 4: a limit, no number (the forecaster's own chance of this, stated with the estimate: 70%); the middle value lies on the limit itself.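

Methyl in place of hydrogen on the oxygen of compound 1 is a single change that leaves the neighbouring methoxy group in place, and in this assay it gives an at least 4.8-fold higher number from compound 1 to compound 4 (0.68 log units; beyond the scatter). Going by these compounds alone, the earlier step from the same compound changed the ring in two ways, so this one ties the move to the limit to the hydroxy hydrogen alone, and compound 1 remains the only compound here with a measured number. The steps linking compound 4 with compound 2 and compound 3 cannot be read, since they join limits: the limit of > 400000 nM in this assay, at which 3 of the 4 values shown sit.

From the compounds shown here alone, how far compound 2, compound 3 and compound 4 lie past that limit, and how they rank, stays unknown. Also open, going by these compounds, is what an amine or a carboxylic acid in place of the hydroxy group would do to the number.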